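A few compounds are considered here, and "the series" means these few. Any claim that something is new, unique, unknown or untested is made for them only; others in the source may bear on it.

Measured in a functional assay on MDA-MB-435 cells (Homo sapiens) for cytotoxicity, read by sulforhodamine B assay, with a stated time of 48 h, tested at 0.1 uM; a lower number here means a stronger effect, a higher number a weaker effect of the compound at the concentration tested:
compound 1 `COc1cc(-c2cc(/C=C/C(=O)c3ccc(N)cc3)[nH]n2)cc(OC)c1OC`: 95%
compound 2 `COc1ccc(-c2cc(/C=C/C(=O)c3ccc(OC)c(OC)c3)[nH]n2)cc1`: 95%
compound 3 `COc1cc(-c2cc(/C=C/C(=O)c3ccc(Cl)c(Cl)c3)[nH]n2)cc(OC)c1OC`: 96%

Compound 1 stands level with compound 2 at the digits printed, the two together the lowest of the three numbers, and compound 3 lies a number 1 percentage points higher from compound 1 to compound 3 (within the scatter), so all three sit within the scatter of one another. Compound 4 `COc1ccc(-c2cc(/C=C/C(=O)c3ccc(N)cc3)[nH]n2)cc1OC` differs from compound 1 in one place: hydrogen in place of methoxy on an aromatic carbon. Going by the values given here, no measured step removes a methoxy from this ring, so no step bears directly on the change. Among the compounds with values here, the only single-site step known is within the scatter, and compound 2, with one methoxy on that ring, shows no change against compound 1 at the digits printed, so no step beyond the scatter is expected in this assay. For compound 4 a value of 95% is estimated, range 85% to 102%. This estimate is expected to mean no change at the digits printed from compound 1 to compound 4 (within the scatter).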

Compound 4, a percentage reported as activity, at one concentration (the size of the read-out at that concentration, not a potency): 98%
The estimate for compound 4 lay 3 percentage points below the measured number; low and high end bracket the measured number.
By their numbers in this assay, from the lowest: compounds 1, 2, 3 and 4 (each within the scatter of the next).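

In this assay, hydrogen in place of methoxy on an aromatic carbon ortho to a methoxy group gives a number 3 percentage points higher from compound 1 to compound 4 (within the scatter). Going by these compounds alone, this is the first single-site step at this position, and it does not separate compound 4 from compound 1 at the concentration tested. No supporting data bear on a cause for this result.

From the compounds shown here alone, it remains open whether an amine, a carboxylic acid or a longer chain such as ethoxy on this carbon would give a step beyond the scatter. Going by these compounds, whether compound 1 and compound 4 separate at other concentrations also remains open.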